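This account rests on a few compounds, and the source may have more. Where it says the series, first, only, none or still open, it means among the compounds named here.

Measured so far:
- Compound 1 `Oc1ccc(-c2cc(-c3cccc(F)c3)cc(-c3cccc(O)c3)n2)cc1`: 3070 nM
- Compound 2 `Oc1ccc(-c2cc(-c3cccc(F)c3)cc(-c3ccc(O)cc3)n2)cc1`: > 50000 nM

These values come from a functional assay on HCT-15 cells (Homo sapiens) for inhibition; a lower number here means a stronger inhibitor, a higher number a weaker inhibitor. Compound 2 gives > 50000 nM, which is a limit of the assay and not a number. Compound 3 `Oc1ccc(-c2cc(-c3ccccc3C(F)(F)F)cc(-c3ccc(O)cc3)n2)cc1` has 2-(trifluoromethyl)phenyl in place of 3-fluorophenyl on an aromatic carbon, opposite the ring nitrogen (2-(trifluoromethyl)phenyl in place of 3-fluorophenyl on an aromatic carbon). Among the measured compounds shown here, the only measured step, an at least 16-fold higher number from compound 1 to compound 2 (1.21 log units; beyond the scatter), is large, but it concerns a hydroxyphenyl group, not the group exchanged here. Compound 3 keeps the two 4-hydroxyphenyl groups, so weak inhibition is expected, with no clear move beyond the scatter. The expected change is an at least 1.4-fold lower number from compound 2 to compound 3 (0.15 log units; that floor lies within the scatter). The estimate for compound 3 is 35000 nM, within an expected range of 10000 nM to 100000 nM.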

Compound 3, half-maximal inhibitory concentration: > 50000 nM
Compound 3 was reported as a limit (the forecaster's own chance of this, stated with the estimate: 50%); middle value at least 1.4-fold (0.15 log units) from the limit.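

Compound 3 gives > 50000 nM, a limit of the assay and not a number, as compound 2 also does, so no step between these two compounds can be read: the limit of > 50000 nM in this assay, at which 2 of the 3 values shown sit.

On these data alone, whether 2-(trifluoromethyl)phenyl in place of 3-fluorophenyl changes inhibition at all stays open.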